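Sulfonamide nitrogen aryl change, compound 2 to compound 3

This account rests on a few compounds, and the source may have more. Where it says the series, first, only, none or still open, it means among the compounds named here.

Measured in a functional assay on cells (leukaemia cell line, Homo sapiens) for inhibition, read by sulforhodamine B assay, with a stated time of 48 h (a higher number here means a weaker inhibitor of growth, a lower number a stronger inhibitor of growth), so far:
- compound 1 `O=S(=O)(Nc1ccccc1Cl)c1ccc(-c2cnc(C3CC3)o2)cc1` gives 429 nM
- compound 2 `O=S(=O)(Nc1cccc(Cl)c1)c1ccc(-c2cnc(C3CC3)o2)cc1` gives 477 nM

In this assay, among the compounds with values here, compound 2 stands within the scatter of compound 1, the only other measured compound. The change to compound 3 `Cc1cc(NS(=O)(=O)c2ccc(-c3cnc(C4CC4)o3)cc2)ccc1Cl` is 4-chloro-3-methylphenyl in place of 3-chlorophenyl on a sulfonamide nitrogen and nothing else. Within the data shown here, the one measured step on this nitrogen is a 1.1-fold higher number from compound 1 to compound 2 (0.05 log units; within the scatter) and it does not test an added methyl. No step beyond the scatter is therefore expected, and the estimated step is a 1.2-fold lower number from compound 2 to compound 3 (0.08 log units; within the scatter) on this evidence. For compound 3 the expected value is 400 nM with an estimated range from 180 nM to 900 nM in this read-out.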

Compound 3, concentration for 50% growth inhibition: 216 nM
The estimate for compound 3 lay 1.9-fold (0.27 log units) above the measured number; low and high end bracket the measured number.
By their numbers in this assay, from the lowest: compounds 3, 1 and 2 (each within the scatter of the next, the first and the last beyond it).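

Within the data shown here, compound 3 gives the first step on this sulfonamide nitrogen beyond the scatter in this assay with a 2.2-fold lower number from compound 2 to compound 3 (0.34 log units; beyond the scatter) and so the aryl group here does respond to change. Against the 2-chlorophenyl compound the reading is a 2.0-fold lower number from compound 1 to compound 3 (0.30 log units; within the scatter) so the separation holds against compound 2 only. Nothing on hand bears on a cause for this step.

The 4-chloro-3-methylphenyl group differs from 3-chlorophenyl in both the methyl and the chlorine placing, and the compounds shown do not part the two. Also open, going by these compounds, is how an amine or a carboxylic acid on this aryl ring would read.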